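Halogen placement on the anilide of a sulfonamide series

A few compounds are considered here, and "the series" means these few. Any claim that something is new, unique, unknown or untested is made for them only; others in the source may bear on it.

Measured so far:
compound 1, `CCc1ccc(NS(=O)(=O)c2ccc(N3CCNC3=O)cc2)cc1`: 480 nM
compound 2, `O=C1NCCN1c1ccc(S(=O)(=O)Nc2ccc(Br)cc2)cc1`: 130 nM
compound 3, `O=C1NCCN1c1ccc(S(=O)(=O)Nc2cccc(Cl)c2)cc1`: 25 nM

Of the compounds shown here, three sharing one core have been tested in a functional assay on M21 cells (Homo sapiens) for antiproliferative activity, read by sulforhodamine B assay, with a stated time of 48 h; on this read-out higher numbers stand for weaker inhibition and lower numbers for stronger inhibition. Compound 3 stands lowest of the three numbers; compound 2 is nearest, at a 5.2-fold lower number from compound 2 to compound 3 (0.72 log units; beyond the scatter), and compound 1 is furthest, at a 19-fold lower number from compound 1 to compound 3 (1.28 log units; beyond the scatter). Between compound 1 and compound 2 the step is a 3.7-fold lower number from compound 1 to compound 2 (0.57 log units; beyond the scatter).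

Compound 4, `O=C1NCCN1c1ccc(S(=O)(=O)Nc2ccc(F)cc2)cc1`, has not yet been measured. It differs from compound 3 in one place: 4-fluorophenyl in place of 3-chlorophenyl on a sulfonamide nitrogen.

Two of the measured steps bear on this change. The step from compound 2 to compound 3 shows that moving a halogen from the 4-position to the 3-position of the anilide ring lowered the number, and the step from compound 1 to compound 2 shows that a 4-halogen gave a lower number than a 4-ethyl group. Going by the values given here, compound 4 returns to a 4-halogen, so the number is expected to rise from that of compound 3 by a modest step, roughly a 7.2-fold higher number from compound 3 to compound 4 (0.86 log units; beyond the scatter), though a smaller halogen than bromine has no precedent here. For compound 4 the estimate in this assay is therefore 180 nM, with a range from 50 nM to 700 nM.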

Compound 4, half-maximal inhibitory concentration: 230 nM
Compound 4: the middle estimate sits 1.3-fold (0.11 log units) below what was measured; the range from low to high includes it.
By their numbers in this assay, from the lowest: compound 3; then compounds 2 and 4 (each within the scatter of the next); then compound 1.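

In this assay, the 4-fluorophenyl group on the sulfonamide nitrogen gives up most of the gain seen with the 3-chlorophenyl group, a change of a 9.2-fold higher number from compound 3 to compound 4 (0.96 log units; beyond the scatter). The halogen on the 4-substituted ring makes no readable difference, since fluoro in place of bromo gives a 1.8-fold higher number from compound 2 to compound 4 (0.25 log units; within the scatter), which lies within the scatter, while fluoro in place of ethyl still gives a 2.1-fold lower number from compound 1 to compound 4 (0.32 log units; beyond the scatter). Compound 3 therefore stands apart from both 4-halophenyl compounds, but its steps to them change the halogen and its place together, so these compounds cannot show which of the two matters more.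

The compounds shown leave open whether a 3-fluorophenyl group would match the 3-chlorophenyl group and whether a 4-chlorophenyl group would stay with compound 2 and compound 4, and they do not show how a methoxy group or an amine would fare on this ring. Nothing among the data given accounts for the differences between these anilides.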